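Swapping one pyridine for another on a weakly active series

The source may report more compounds than this note shows. Statements on the series, on what has been measured and on what is new or still open speak of the compounds shown alone.

Compound 1 `C=CS(=O)(=O)N1CCN(c2ncnc3sc(-c4ccccc4)cc23)CC1`: 54200 nM
Compound 2 `C=CS(=O)(=O)N1CCN(c2ncnc3sc(-c4cccc5ccccc45)cc23)CC1`: 23700 nM
Compound 3 `C=CS(=O)(=O)N1CCN(c2ncnc3sc(-c4ccnc(Cl)c4)cc23)CC1`: 27700 nM

These values come from a functional assay on MDA-MB-231 cells (Homo sapiens) for antiproliferative activity, read by MTT assay, with a stated time of 48 h; on this read-out lower numbers stand for stronger inhibition and higher numbers for weaker inhibition. All three compounds share a core and differ only in the aromatic group on it. Where compound 3 stands is best told by its gaps to the other two. On one side there is a 2.0-fold lower number from compound 1 to compound 3 (0.29 log units; within the scatter). On the other there is a 1.2-fold higher number from compound 2 to compound 3 (0.07 log units; within the scatter). Compound 3 therefore cannot be told apart from either neighbour, although those neighbours do differ from each other.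

Compound 4 `C=CS(=O)(=O)N1CCN(c2ncnc3sc(-c4ccc(F)nc4)cc23)CC1` changes that aromatic group once more: 6-fluoropyridin-3-yl in place of 2-chloropyridin-4-yl on an aromatic carbon. In words, 6-fluoropyridin-3-yl comes in place of 2-chloropyridin-4-yl, on the aromatic carbon next to the ring sulfur.

Going by the values given here, no measured step tests this exact swap, so the nearest guide is the other changes at the same place. The largest of them is a 2.3-fold lower number from compound 1 to compound 2 (0.36 log units; beyond the scatter), which is only modest. With so small a largest step, no change beyond the scatter is expected in this assay. The expected step is a 1.1-fold higher number from compound 3 to compound 4 (0.03 log units; within the scatter). For compound 4 the estimate is 30000 nM, with an expected range from 14000 nM to 62000 nM.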

Compound 4, half-maximal inhibitory concentration: 16000 nM
Compound 4: middle estimate off by 1.9-fold (0.27 log units), on the high side, and the stated range covers the measured number.
By their numbers in this assay, from the lowest: compounds 4, 2, 3 and 1 (each within the scatter of the next, the first and the last beyond it).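

With 6-fluoropyridin-3-yl on the aromatic carbon next to the ring sulfur, this assay shows a 3.4-fold lower number from compound 1 to compound 4 (0.53 log units; beyond the scatter) and so, although the step is modest, this is the only pyridine shown that separates from phenyl at this position. Compound 4 still cannot be told apart from its other two neighbours: replacing 2-chloropyridin-4-yl gives a 1.7-fold lower number from compound 3 to compound 4 (0.24 log units; within the scatter) and replacing naphthalen-1-yl gives a 1.5-fold lower number from compound 2 to compound 4 (0.17 log units; within the scatter) which means that a pyridine and a naphthalene group cannot be separated here, and neither can these two pyridines. No measurement at hand offers an explanation for any of these numbers.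

The swap from compound 3 to compound 4 exchanges chlorine for fluorine and also moves from a pyridin-4-yl to a pyridin-3-yl group, so the compounds shown cannot say which of these two changes matters, if either does. On these data alone, a plain pyridin-3-yl, a 4-fluorophenyl or a 6-aminopyridin-3-yl group at the same carbon would help to pull those changes apart, and whether any group here can bring the numbers far below this high range remains open.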